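Working notes on a fluoronaphthyl pyridinone series

The compounds below may be only part of what the source reports. "The series", "measured", "known", "first", "only" and "open" are said of these compounds alone.

Measured so far:
- compound 1 `CC(C)C(c1ccc(-c2ccc3cccc(F)c3c2)[nH]c1=O)N1CCN/C1=N\C#N` — 38 nM
- compound 2 `CC(C)NC(=O)CC(c1ccc(-c2ccc3cccc(F)c3c2)[nH]c1=O)C(C)C` — 15 nM

Compound 2 carries the lowest of the two numbers in a functional assay on CHO cells for antagonist activity at prostaglandin E2 receptor EP3 subtype (Homo sapiens), read by cAMP accumulation (a lower number here means a stronger inhibitor, a higher number a weaker inhibitor), and compound 1 sits a step away from it, a 2.5-fold lower number from compound 1 to compound 2 (0.40 log units; beyond the scatter). Compound 3 `CC(C)C(/C=C1\CCNC1=O)c1ccc(-c2ccc3cccc(F)c3c2)[nH]c1=O` departs from compound 2 by a group of 7 heavy atoms (5 carbon, 1 nitrogen, 1 oxygen; one five-membered non-aromatic ring with 1 hetero atom) in place of a group of 7 heavy atoms (5 carbon, 1 nitrogen, 1 oxygen; no ring), on a saturated chain carbon bound to an aromatic carbon and a saturated chain carbon. Among the compounds with values here, no measured step repeats this exchange; the only step touching this position, the one from compound 1 to compound 2, was modest. The change is therefore expected to shift this assay little, with a slight loss possible, a 1.7-fold higher number from compound 2 to compound 3 (0.22 log units; within the scatter). Compound 3 is estimated at 25 nM, within 8 nM to 80 nM.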

Compound 3, half-maximal inhibitory concentration: 8.7 nM
Beside the measured number, compound 3's estimate is 2.9-fold (0.46 log units) above it; low and high end bracket the measured number.
By their numbers in this assay, from the lowest: compounds 3 and 2 (each within the scatter of the next); then compound 1.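

In this assay, replacing the open (isopropylcarbamoyl)methyl with the five-membered non-aromatic ring of equal heavy-atom count gives a 1.7-fold lower number from compound 2 to compound 3 (0.24 log units; within the scatter), so this position accepts the ring form of the group without a step beyond the scatter. Two five-membered non-aromatic rings at this place are also not equivalent: the ring with 1 hetero atom gives a 4.4-fold lower number from compound 1 to compound 3 (0.64 log units; beyond the scatter). No supporting data explain either step.

Open, as far as these compounds go, is how a carboxylic acid or a simple amine would read at this saturated chain carbon. Also open, from the compounds shown here alone, is whether the added double bond matters apart from the ring.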